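Same Amino Substitution, Tried on a Second Core

This account rests on a few compounds, and the source may have more. Where it says the series, first, only, none or still open, it means among the compounds named here.

Measured compounds:
compound 1, `ClCc1ccc(Cn2cnc3c(Cl)ncnc32)cc1`: 3460 nM
compound 2, `Nc1nc(Cl)c2ncn(Cc3ccc(CCl)cc3)c2n1`: 38000 nM
compound 3, `ClCc1ccccc1Cn1cnc2c(Cl)ncnc21`: 3710 nM

All three were tested in a functional assay on M14 cells (Homo sapiens) for cytotoxicity, read by sulforhodamine B assay, with a stated time of 48 h; a higher number here means a weaker inhibitor of growth, a lower number a stronger inhibitor of growth. Compound 1 and compound 2 differ in one place: amino in place of hydrogen on an aromatic carbon. This change produced an 11-fold higher number from compound 1 to compound 2 (1.04 log units; beyond the scatter), a large step that weakens growth inhibition. It lies well beyond the usual scatter of repeated measurements.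

Compound 3 has the same atoms as compound 1, joined differently; the difference between the two cores is not broken down here. Their values in this assay lie within the usual scatter of each other, so nothing can be said about which of the two is the stronger inhibitor.

Compound 4, `Nc1nc(Cl)c2ncn(Cc3ccccc3CCl)c2n1`, has not yet been measured. It differs from compound 3 in exactly the way compound 2 differs from compound 1: amino in place of hydrogen on an aromatic carbon. The surroundings of the change are described in the same words in both cases, so this is the same change applied to a second core.

The expectation for compound 4 rests on a single earlier example. The step estimated here is an 11-fold higher number from compound 3 to compound 4 (1.03 log units; beyond the scatter), expected because the same change gave an 11-fold higher number from compound 1 to compound 2 (1.04 log units; beyond the scatter). Among the compounds with values here, with only one precedent, the estimate carries considerable uncertainty.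

Compound 4 is therefore estimated at 40000 nM in this assay, with a likely range from 15000 nM to 100000 nM.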

Compound 4, concentration for total growth inhibition: 39800 nM
Compound 4: the middle estimate sits 1.0-fold (0.00 log units) above what was measured, and the stated range covers the measured number.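

In this assay, amino in place of hydrogen on an aromatic carbon gave an 11-fold higher number from compound 3 to compound 4 (1.03 log units; beyond the scatter), a large step that weakens growth inhibition on this second core. Compared with the earlier example, the step kept its size when the change moved from the core of compound 1 to the core of compound 3: the same change on two cores in this assay, an 11-fold higher number (1.04 log units; beyond the scatter) from compound 1 to compound 2 and an 11-fold higher number (1.03 log units; beyond the scatter) from compound 3 to compound 4, 1.0-fold (0.01 log units) apart, within the scatter of two such steps This shows that, in this one cell assay, the change behaved alike on two cores built from the same atoms joined differently, but two examples cannot show that it would do so on a core of another kind, and they do not explain why growth inhibition weakens.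

The compounds shown leave open whether a different group on that same aromatic carbon, such as a methylamino group or a hydroxyl group, would give a step of similar size or a smaller one. They also leave open whether the amino step would stay the same if a methyl group stood in place of the chloromethyl group, since both pairs carry the chloromethyl group.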